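Sulfonyl series: trifluoromethyl in place of chloro

This account rests on a few compounds, and the source may have more. Where it says the series, first, only, none or still open, it means among the compounds named here.

Measured in a functional assay on MDA-MB-231 cells (Homo sapiens) for inhibition, read by sulforhodamine B assay, with a stated time of 74 h; a lower number here means a stronger inhibitor, a higher number a weaker inhibitor:
- compound 1 `Cc1ccccc1S(=O)(=O)N1C(=O)COC12C=CC(=O)C=C2`: > 10000 nM (a limit)
- compound 2 `O=C1C=CC2(C=C1)OCC(=O)N2S(=O)(=O)c1ccc(Cl)cc1`: 2800 nM
- compound 3 `O=C1C=CC2(C=C1)OCC(=O)N2S(=O)(=O)c1ccc(F)c(F)c1`: > 10000 nM (a limit)

Among the compounds with values here, compound 2 gives 2800 nM, the only true number in the set. Compound 1 and compound 3 both stand at the limit of > 10000 nM in this assay, at which 2 of the 3 values shown sit.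

Compound 4 `O=C1C=CC2(C=C1)OCC(=O)N2S(=O)(=O)c1ccc(C(F)(F)F)cc1` follows from compound 2 through trifluoromethyl in place of chloro on an aromatic carbon, para to a large group. Within the data shown here, the only measured step is an at least 3.5-fold lower number from compound 1 to compound 2 (0.55 log units; beyond the scatter). It involves a different exchange on the sulfonyl sulfur, so it shows that the aryl group can matter but gives no size for this change. The expected change is a 1.3-fold higher number from compound 2 to compound 4 (0.10 log units; within the scatter), which means no step beyond the scatter is expected in this assay. For compound 4 the estimate is 3500 nM, with an expected range of 1200 nM to 10000 nM.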

Compound 4, half-maximal inhibitory concentration: 2100 nM
Beside the measured number, compound 4's estimate is 1.7-fold (0.22 log units) above it; the range from low to high includes it.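

In this assay, trifluoromethyl in place of chloro on an aromatic carbon, para to a large group, gives a 1.3-fold lower number from compound 2 to compound 4 (0.12 log units; within the scatter), so the two groups cannot be told apart at this position. Compound 4 thus provides a second true number in the set, alongside compound 2. Compound 1 and compound 3 remain limits, not numbers: the limit of > 10000 nM in this assay, at which 2 of the 4 values shown sit.

As far as these compounds go, whether an amine, a carboxylic acid or a methoxy group at this position would keep a true number stays open. With only chloro and trifluoromethyl readable here, no trend across groups can be drawn.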